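The source may hold more compounds than are shown below. What is called first, only, known or untested is meant among the compounds shown, and "the series" means these compounds.

Compound 1 `COc1cc(C(=O)/C=C/c2cc(O)ccc2O)cc(OC)c1OC` heads the set. In a functional assay on COLO 205 cells (Homo sapiens) for inhibition, read by MTT assay, with a stated time of 48 h (on this read-out higher numbers stand for weaker inhibition and lower numbers for stronger inhibition), compound 1 gives > 100000 nM, which is a limit of the assay rather than a number (the limit of > 100000 nM in this assay, at which 1 of the 2 values shown sits). Compound 2 `COc1cc(C(=O)/C=C/c2ccc(Br)cc2)cc(OC)c1OC` gives 22500 nM in this assay. Going by the values given here, the single measured step bearing on the series is an at least 4.4-fold lower number from compound 1 to compound 2 (0.64 log units; beyond the scatter), read off from a limit. Compound 3 `COc1cc(C(=O)/C=C/c2cc([N+](=O)[O-])ccc2O)cc(OC)c1OC` differs from compound 1 by nitro in place of hydroxy on an aromatic carbon. For this change the expected step is an at least 2.5-fold lower number from compound 1 to compound 3 (0.39 log units; beyond the scatter), toward a lower number. Compound 3 is therefore estimated at 40000 nM, in the range 10000 nM to 120000 nM.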

Compound 3, half-maximal inhibitory concentration: 76000 nM
Beside the measured number, compound 3's estimate is 1.9-fold (0.28 log units) below it; the measured number falls inside the stated range.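

Nitro in place of hydroxy on this aromatic carbon, para to a hydroxy group, gives a number that can be read in this assay, which compound 1 does not. The change is only bounded, as an at least 1.3-fold lower number from compound 1 to compound 3 (0.11 log units; that floor lies within the scatter), so no real gain is established. For compound 1 the value is a limit and not a number: the limit of > 100000 nM in this assay, at which 1 of the 3 values shown sits.

Still open, on these data alone, is how an amine or a carboxylic acid on this carbon would read, and what removing the remaining hydroxy group would do with nitro kept in place.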